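This account rests on a few compounds, and the source may have more. Where it says the series, first, only, none or still open, it means among the compounds named here.

Within the data shown here, in a functional assay on the whole organism (strain albino) for inhibition, with Rattus norvegicus as the target, read by paw edema, with a stated time of 180 min, at a dose of 100 mg/kg by the oral route (on this read-out lower numbers stand for less inhibition and higher numbers for more inhibition at the one dose given (going by the name of the read-out)), compound 2 `c1ccc(NCc2nc3ccccc3[nH]2)cc1` gives 38.8%, the higher of the two numbers measured so far. Compound 1 `Brc1ccc(NCc2nc3ccc(Br)cc3[nH]2)cc1` gives 16.6%, a number lower than that of compound 2 by more than the usual scatter; the two structures differ in more than one place, so only their two values can be set side by side. Compound 3 `Brc1ccc(NCc2nc3ccccc3[nH]2)cc1` has not yet been measured in this assay. It differs from compound 2 by bromo in place of hydrogen on an aromatic carbon. A modest downward step is expected, a number 10.8 percentage points lower from compound 2 to compound 3 (beyond the scatter), partly because compound 1 gives 16.6%. Compound 3 is estimated at 28%, within 12% to 42%.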

Compound 3, a percentage reported as inhibition, in the whole organism at one dose (the size of the read-out at that dose, not a potency): 29.4%
Compound 3: middle estimate off by 1.4 percentage points, on the low side, and the stated range covers the measured number.
By their numbers in this assay, from the lowest: compound 1; then compounds 3 and 2 (each within the scatter of the next).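

In this assay, bromo in place of hydrogen on this aromatic carbon, para to a large group, gives a number 9.4 percentage points lower from compound 2 to compound 3 (within the scatter), so this single change cannot be told apart from the scatter. Taking away the other bromo of compound 1 gives a number 12.8 percentage points higher from compound 1 to compound 3 (beyond the scatter), which shows a single change in this series that does exceed the scatter, at that other place.

Going by these compounds, whether an amine, a methoxy group or a carboxylic acid at the same position would move the number beyond the scatter remains open. Nothing available explains why the two bromo changes differ in size.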